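The source may hold more compounds than are shown below. What is called first, only, known or untested is meant among the compounds shown, and "the series" means these compounds.

Working notes on the series. Of the compounds shown here, two on the shared core have been measured. Compound 1 `CCc1cc(C(=O)OCO[P@@]2(=O)OCC(C)(C)[C@H](C(=O)NCCC(=O)OC)O2)n(C)n1` and compound 2 `CCOC(=O)CCNC(=O)[C@@H]1O[P@@](=O)(OCOC(=O)C(C)(C)C)OCC1(C)C` were both run in an ADME assay on blood (Homo sapiens) for pharmacokinetics; a higher number here means that the compound lasts longer, a lower number that the compound disappears faster. In this assay compound 1 gives >= 0.97 h, which is a limit of the assay and not a number. In this assay compound 2 gives 0.28 h. For the measured compounds named here, compound 1 therefore stands at the limit of >= 0.97 h in this assay, at which 1 of the 2 values shown sits, the upper of the two values shown, while compound 2 sits at a measured number; the two compounds differ in more than one place, so no single step between them is stated, and only what the two values show is recorded here.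

Compound 3 `COC(=O)CCNC(=O)[C@@H]1O[P@@](=O)(OCOC(=O)c2ocnc2C)OCC1(C)C` has not yet been measured in this assay. It differs from compound 1 in one place: 4-methyl-1,3-oxazol-5-yl in place of 3-ethyl-1-methyl-1H-pyrazol-5-yl on a carbonyl carbon. Going by the values given here, no measured step of this kind exists, so the step from compound 1 to compound 3 in this assay is expected to be an at least 1.0-fold lower number from compound 1 to compound 3 (0.03 log units; that floor lies within the scatter), a change that should stay within the usual scatter and whose direction cannot be fixed from the numbers at hand. On that basis compound 3 is estimated in this assay at 0.9 h, with an expected range from 0.35 h to 2.5 h.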

Compound 3, half-life: 0.52 h
For compound 3 the middle estimate is 1.7-fold (0.24 log units) above the measured one; low and high end bracket the measured number.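

For the compounds shown here, replacing 3-ethyl-1-methyl-1H-pyrazol-5-yl with 4-methyl-1,3-oxazol-5-yl on a carbonyl carbon gives the first readable step at this position in this assay, an at least 1.8-fold lower number from compound 1 to compound 3 (0.27 log units; that floor lies within the scatter), and the exchange keeps one five-membered aromatic ring with 2 hetero atoms and the same counts of hydrogen-bond donors and acceptors while the group goes from 8 to 6 heavy atoms. For compound 1 the value >= 0.97 h is a limit of the assay and not a number. The step can be read only as a floor that does not establish a change beyond the scatter, and its full size stays unknown, because compound 1 sits at a limit: the limit of >= 0.97 h in this assay, at which 1 of the 3 values shown sits.

From the compounds shown here alone, whether the real gap for this exchange lies beyond the scatter remains open, as does which part of either ring, such as the ethyl group or the ring oxygen, matters for the half-life. Also open, going by these compounds, is how the half-life responds when a phenyl ring or a dimethylamino group stands on this carbonyl carbon.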